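Stripping the Side Chain from a Phosphatase Inhibitor Scaffold

The compounds below may be only part of what the source reports. "The series", "measured", "known", "first", "only" and "open" are said of these compounds alone.

Compound 1 `CCN(CC)C(=O)COc1ccc2cc(C(O)(C(F)(F)F)C(F)(F)F)c(O)cc2c1` and compound 2 `O=C(COc1ccc2cc(C(O)(C(F)(F)F)C(F)(F)F)c(O)cc2c1)NC1CC1` share one core and differ only at a carbonyl carbon, where compound 2 carries cyclopropylamino in place of diethylamino. In an assay on isolated protein for inhibition of tyrosine-protein phosphatase non-receptor type 13 (Homo sapiens), read by spectrophotometry (a lower number here means a stronger inhibitor, a higher number a weaker inhibitor), compound 1 reaches only the limit > 20000 nM. In this assay compound 2 likewise sits at the limit > 20000 nM. The step that the two limits leave unreadable from compound 1 to compound 2 cannot be sized, since (the limit of > 20000 nM in this assay, at which 2 of the 2 values shown sit). Compound 2 thus stands at the limit of the assay, with no number to place it against.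

Compound 3 `Oc1cc2ccccc2cc1C(O)(C(F)(F)F)C(F)(F)F` has not been measured in this assay; it differs from compound 2 by hydrogen in place of (cyclopropylcarbamoyl)methoxy on an aromatic carbon, so that the whole (cyclopropylcarbamoyl)methoxy group is gone and only the shared core remains. Within the data shown here, no measured step bears directly on this change: the single step on record, a step that the two limits leave unreadable from compound 1 to compound 2, touches the amide end of that chain and lies unreadable between two limits. With both measured compounds at the limit, the expected step in this assay is a step that the limit leaves unreadable from compound 2 to compound 3, none beyond the scatter. Compound 3 is therefore estimated at 30000 nM, within 5000 nM to 200000 nM, most probably reported again only as a limit.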

Compound 3, half-maximal inhibitory concentration: 128000 nM
Compound 3: middle estimate off by 4.3-fold (0.63 log units), on the low side; measured number inside the range.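

Among these compounds, compound 3 gives a number in this assay, yet no step from compound 1 or compound 2 to compound 3 can be read, because both of those compounds stand only at a limit: the limit of > 20000 nM in this assay, at which 2 of the 3 values shown sit. The compounds shown leave open whether either (cyclopropylcarbamoyl)methoxy or (diethylcarbamoyl)methoxy on the shared core changes inhibition at all.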